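Shortening a Butyl Chain on a Biaryl Acid

The compounds below may be only part of what the source reports. "The series", "measured", "known", "first", "only" and "open" are said of these compounds alone.

Measured compounds:
- Compound 1, `Cc1cc(O)cc(C)c1-c1cccc(COc2ccc(OCC(=O)O)c(F)c2)c1`: 110 nM
- Compound 2, `Cc1cc(OC(C)C)cc(C)c1-c1cccc(COc2ccc(OCC(=O)O)c(F)c2)c1`: "not determined" (no result reported)
- Compound 3, `CCCCOc1cc(C)c(-c2cccc(COc3ccc(OCC(=O)O)c(F)c3)c2)c(C)c1`: "not determined" (no result reported)

All three share one core, which in compound 1 carries a hydroxyl group. Going by the values given here, in a functional assay on CHO cells for agonist activity at Free fatty acid receptor 1 (Homo sapiens), read by FLIPR and calcium flux (a lower number here means that less compound is needed, a higher number that more compound is needed for the effect), compound 1 gives 110 nM, and it is the only compound with a number. Compound 2 has no result in this assay, and compound 3, with a butoxy group in place of the hydroxyl, likewise has no result. So compound 3 stands without a value, and no step between measured compounds can be read.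

Compound 4, `CCCOc1cc(C)c(-c2cccc(COc3ccc(OCC(=O)O)c(F)c3)c2)c(C)c1`, differs from compound 3 in a single place: hydrogen in place of methyl on a saturated chain carbon, three bonds along the chain from an oxygen on an aromatic ring. The change is small and lies on a saturated chain carbon. Among the compounds with values here, with no measured step to guide it, the expected shift in this assay is none beyond the scatter, in either direction. Compound 4 is expected to give about 100 nM in this assay, with a range from 30 nM to 400 nM, resting on compound 1 and its value 110 nM.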

Compound 4, half-maximal effective concentration: 106 nM
Estimate against measurement, compound 4: 1.1-fold (0.03 log units) below, and the stated range covers the measured number.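

In this assay, the change from hydrogen to propyl on the oxygen on an aromatic ring gives a 1.0-fold lower number from compound 1 to compound 4 (0.02 log units; within the scatter) and so amounts to no real change. Going by these compounds alone, until now the only number at this place belonged to the free hydroxyl of compound 1, whereas compound 4 shows that this oxygen can carry a propyl chain with agonist activity still readily measured. A chain on this oxygen is therefore compatible with activity, at least for propyl.

Going by these compounds, the steps to compound 2 and compound 3 cannot be read, so it stays open how butyl compares with propyl and how a longer chain such as pentyl, or a chain ending in an amine or a carboxylic acid, would behave on this oxygen. Nothing shown offers a reason why the number stays level here.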